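Working notes: from compound 3 to compound 4

The source may hold more compounds than are shown below. What is called first, only, known or untested is meant among the compounds shown, and "the series" means these compounds.

Measured in a functional assay on the whole organism for antagonist activity, with Mus musculus as the target; on this read-out lower numbers stand for an effect already at smaller amounts and higher numbers for an effect only at larger amounts of compound
- compound 1 (`CCSc1nnc(-c2ccccc2)n1C`) gives > 200 mg/kg
- compound 2 (`CC[S+]([O-])c1nnc(-c2ccccc2)n1C`) gives > 200 mg/kg
- compound 3 (`CSc1nnc(-c2cccc3ccccc23)n1C`) gives > 200 mg/kg

Each of these entries is a limit and not a number. Compound 3 stands at > 200 mg/kg and this is a limit. Going by the values given here, the series so far shows the limit of > 200 mg/kg in this assay, at which 3 of the 3 values shown sit, and no compound has yet given a number.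

The next structure is compound 4 (`Cn1c(-c2cccc3ccccc23)nnc1[S+](C)[O-]`), where methylsulfanyl leaves. The change is a group of 3 heavy atoms (1 carbon, 1 oxygen, 1 sulfur; no ring) in place of a group of 2 heavy atoms (1 carbon, 1 sulfur; no ring), on an aromatic carbon on the shared core.

Among the compounds with values here, the one measured step of a similar kind is a step that the two limits leave unreadable from compound 1 to compound 2 and it offers no size to carry over. No direction can be read from it either. In this assay the estimated step is a step that the limit leaves unreadable from compound 3 to compound 4 and nothing beyond the scatter is expected, with another limit the likeliest report. For compound 4 the expected value is 250 mg/kg and the estimated range runs from 120 mg/kg to 500 mg/kg for the measurement.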

Compound 4, dose for half-maximal effect: > 200 mg/kg
Compound 4 ended at the assay's limit; the forecaster's own chance of this, stated with the estimate: 85%; the middle value is on the limit's open side.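

In this assay compound 3 and compound 4 both give a limit and not a number, so no step between them can be read: the limit of > 200 mg/kg in this assay, at which 4 of the 4 values shown sit.

The compounds shown leave open whether any change on the shared core gives a number in this assay at all.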